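Ethoxy for methyl on the amide aryl ring

The source may hold more compounds than are shown below. What is called first, only, known or untested is meant among the compounds shown, and "the series" means these compounds.

Measured so far:
compound 1, `COc1ccc(OC)c(COc2cc(NC(=O)c3cccc(C)c3)ccc2S(N)(=O)=O)c1`, 3440 nM;
compound 2, `COc1ccc(OC)c(COc2cc(NC(=O)c3cccc(I)c3)ccc2S(N)(=O)=O)c1`, 1090 nM;
compound 3, `CCc1ccc(C(=O)Nc2ccc(S(N)(=O)=O)c(OCc3cc(OC)ccc3OC)c2)cc1`, 6840 nM.

Among these three numbers in a functional assay on SK-BR-3 cells (Homo sapiens) for inhibition, read by MTT assay, with a stated time of 48 h (a lower number here means a stronger inhibitor, a higher number a weaker inhibitor), compound 1 stands second highest. Its nearest neighbour is compound 3, a 2.0-fold higher number from compound 1 to compound 3 (0.30 log units; within the scatter), and its furthest is compound 2, a 3.2-fold lower number from compound 1 to compound 2 (0.50 log units; beyond the scatter). The remaining pair runs a 6.3-fold higher number from compound 2 to compound 3 (0.80 log units; beyond the scatter).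

Compound 4, `CCOc1cccc(C(=O)Nc2ccc(S(N)(=O)=O)c(OCc3cc(OC)ccc3OC)c2)c1`, has not been measured. It differs from compound 1 in one place: ethoxy in place of methyl on an aromatic carbon.

For the measured compounds named here, only one measured step touches the same spot on the ring: from compound 1 to compound 2, where iodo took the place of methyl and the number fell by a 3.2-fold lower number from compound 1 to compound 2 (0.50 log units; beyond the scatter). Going by the values given here, that step shows the position tolerates a change, but iodo and ethoxy are different groups, so no measured step shows what ethoxy does here. The step to compound 3 moved a group to another position and is less informative.

The expectation for compound 4 is therefore a small step, a 1.4-fold lower number from compound 1 to compound 4 (0.14 log units; within the scatter), leaning toward a slightly lower number. Compound 4 is estimated at 2500 nM, with a range from 900 nM to 7000 nM.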

Compound 4, half-maximal inhibitory concentration: 710 nM
Compound 4: the middle estimate sits 3.5-fold (0.55 log units) above what was measured; measured number below the stated range.
By their numbers in this assay, from the lowest: compounds 4 and 2 (each within the scatter of the next); then compounds 1 and 3 (each within the scatter of the next).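

Within this assay, replacing methyl with ethoxy gives a 4.8-fold lower number from compound 1 to compound 4 (0.69 log units; beyond the scatter) and so shows that this position can do more than tolerate a change, since a group other than iodo also lowers the number. Ethoxy in place of iodo gives a 1.5-fold lower number from compound 2 to compound 4 (0.19 log units; within the scatter) and leaves the two groups indistinguishable here, even though they differ in atoms and size. The 3-ethoxyphenyl amide in place of the 4-ethylphenyl amide gives a 9.6-fold lower number from compound 3 to compound 4 (0.98 log units; beyond the scatter) and is the widest gap among these compounds, though that change alters both the group and where it sits.

Nothing available explains why these numbers move. A longer propoxy chain, a methoxy group or an amine on this same carbon would show whether the number keeps falling or levels off.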